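Amide aryl swap on the bis-tetrahydrofuran acetogenin-like chain

A few compounds are considered here, and "the series" means these few. Any claim that something is new, unique, unknown or untested is made for them only; others in the source may bear on it.

Measured so far:
compound 1, `CCCCCCCCCCCC[C@@H](O)[C@H]1CC[C@H]([C@H](O)CCCCCCCCCCNC(=O)c2ccsc2)O1`: 2290 nM
compound 2, `CCCCCCCCCCCC[C@@H](O)[C@H]1CC[C@H]([C@H](O)CCCCCCCCCCNC(=O)c2ccnn2C)O1`: 43700 nM

Compound 2 holds the higher of the two numbers measured in a functional assay on MKN-1 cells (Homo sapiens) for inhibition, read by colorimetric assay and sulforhodamine B assay, with a stated time of 48 h; a lower number here means a stronger inhibitor of growth, a higher number a weaker inhibitor of growth; its nearest neighbour is compound 1, and the gap a 19-fold higher number from compound 1 to compound 2 (1.28 log units; beyond the scatter) lies beyond the scatter. For the measured compounds named here, the only change between those two is the aryl group on the carbonyl carbon of the amide, so that single measured step is the whole of what is known about this position.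

Compound 3, `CCCCCCCCCCCC[C@@H](O)[C@H]1CC[C@H]([C@H](O)CCCCCCCCCCNC(=O)c2cccs2)O1`, is not yet measured. Its difference from compound 2 is thiophen-2-yl in place of 1-methyl-1H-pyrazol-5-yl on a carbonyl carbon. Going by the values given here, the one step that bears on it is a 19-fold higher number from compound 1 to compound 2 (1.28 log units; beyond the scatter), which reversed from the pyrazole back to a thiophene gave a large change. Compound 3 carries a thiophene again, attached through a different ring carbon than in compound 1, so the expectation is a large step down from compound 2, roughly undoing that earlier step, with some allowance for the shifted attachment: a 15-fold lower number from compound 2 to compound 3 (1.16 log units; beyond the scatter) is expected. Compound 3 is therefore estimated at 3000 nM in this assay, in the range 1200 nM to 9000 nM.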

Compound 3, concentration for 50% growth inhibition: 1820 nM
The estimate for compound 3 lay 1.6-fold (0.22 log units) above the measured number, and the stated range covers the measured number.
By their numbers in this assay, from the lowest: compounds 3 and 1 (each within the scatter of the next); then compound 2.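

In this assay, the swap at this carbonyl carbon now also reads in the other direction, with thiophen-2-yl in place of 1-methyl-1H-pyrazol-5-yl giving a 24-fold lower number from compound 2 to compound 3 (1.38 log units; beyond the scatter) as a second large step, so the gap between pyrazole and thiophene does not depend on a single thiophene attachment. The attachment point of the thiophene itself shows no separation, since thiophen-2-yl in place of thiophen-3-yl gives a 1.3-fold lower number from compound 1 to compound 3 (0.10 log units; within the scatter) in this assay and the two amides cannot be ranked against each other. Nothing measured on these compounds speaks to what lies behind the gap between the thiophene amides and the pyrazole amide.

With a single pyrazole among the compounds shown, it remains open whether the higher number of compound 2 belongs to the pyrazole ring as such or to its methyl group, and a pyrazole without that methyl would separate the two. Also open, from the compounds shown here alone, is whether a phenyl, furan-2-yl or pyridine ring on the same carbonyl would stay with the thiophenes or move toward the pyrazole.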